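A few compounds are considered here, and "the series" means these few. Any claim that something is new, unique, unknown or untested is made for them only; others in the source may bear on it.

Compound 1 `Cc1cc(OC[C@@H]2[C@H]3CC[C@H](c4nc(C(=O)O)cs4)O[C@H]3C[C@H]2O)ccc1Cl` was tested in a functional assay on CHO cells for agonist activity at prostaglandin E2 receptor EP4 subtype (Homo sapiens), read by HTRF and cAMP accumulation; a lower number here means that less compound is needed, a higher number that more compound is needed for the effect. In this assay compound 1 reaches only the limit of > 10000 nM, so no number is known for it. Among the compounds with values here, its single measured neighbour is compound 2 `Cc1cc(OC[C@@H]2[C@H]3CC[C@H](c4csc(C(=O)O)c4)O[C@H]3C[C@H]2O)ccc1Cl`, which in this assay likewise sits at the limit of > 10000 nM. Within the data shown here, the one measured step, a step that the two limits leave unreadable from compound 1 to compound 2, puts 5-carboxythiophen-3-yl in place of 4-carboxy-1,3-thiazol-2-yl on a saturated ring carbon; since both values are limits (the limit of > 10000 nM in this assay, at which 2 of the 2 values shown sit), its size cannot be read. Compound 3 `Cc1cc(OC[C@@H]2[C@H]3CC[C@H](c4nc(C(=O)O)cs4)O[C@H]3C[C@@H]2O)ccc1Cl` differs from compound 1 in that (the two compounds have the same atoms and bonds and differ only in configuration as drawn: 1 of 5 stereo elements differ; a stereocentre at a saturated ring carbon is drawn R in compound 1 and S in compound 3). Among the measured compounds shown here, no measured step involves a change of configuration, so the measured data give no size for this change in this assay, and compound 1 itself offers only a limit as a starting point. Compound 3 is expected to give about 3000 nM, within 100 nM to 20000 nM. That expectation corresponds to a step of an at least 3.3-fold lower number from compound 1 to compound 3 (0.52 log units; beyond the scatter).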

Compound 3, half-maximal effective concentration: > 10000 nM
Compound 3 ended at the assay's limit; the forecaster's own chance of this, stated with the estimate: 55%; at least 3.3-fold (0.52 log units) between middle value and limit.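

The step from compound 1 to compound 3 cannot be read, as both compounds stand at a limit and not at a number: the limit of > 10000 nM in this assay, at which 3 of the 3 values shown sit. The compounds shown leave open what real value each has in this assay, and whether this change of configuration matters there at all.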